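Trimethoxybenzyl for trifluoromethylbenzyl on a piperazine chain

The compounds below may be only part of what the source reports. "The series", "measured", "known", "first", "only" and "open" are said of these compounds alone.

Two compounds share a core bearing a methyl ester, an isopropyl group and a three-carbon chain to a basic nitrogen. Compound 1 `COC(=O)C(CCCN(C)CCCc1nc2cc(OC)ccc2[nH]1)(c1ccc(OC)cc1)C(C)C` carries an open-chain amine and a benzimidazole, while compound 2 `COC(=O)C(CCCN1CCN(Cc2cccc(C(F)(F)F)c2)CC1)(c1ccc(Br)cc1)C(C)C` carries a piperazine with a 3-(trifluoromethyl)phenyl group on its chain carbon. In a functional assay on HEK293 cells for antagonist activity at Voltage-dependent T-type calcium channel subunit alpha-1G (Homo sapiens), read by patch clamp (a lower number here means a stronger inhibitor, a higher number a weaker inhibitor), compound 1 gives 880 nM and compound 2 gives 280 nM. Compound 2 thus stands at the lower of the two numbers, and the gap to compound 1 lies beyond the usual scatter of this assay.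

Compound 3 `COC(=O)C(CCCN1CCN(Cc2ccc(OC)c(OC)c2OC)CC1)(c1ccc(Br)cc1)C(C)C` is compound 2 with one change: 2,3,4-trimethoxyphenyl in place of 3-(trifluoromethyl)phenyl on a saturated chain carbon bound to an amine nitrogen in a ring. Within the data shown here, no step between two measured compounds shows what this exchange does. The account rests on compound 2 alone, because its value of 280 nM is the only direct reference.

The step from compound 2 to compound 3 is expected to be small, a 2.1-fold higher number from compound 2 to compound 3 (0.33 log units; beyond the scatter), toward a somewhat higher number. Compound 3 is therefore estimated at 600 nM in this assay, with a range from 200 nM to 2000 nM.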

Compound 3, half-maximal inhibitory concentration: 320 nM
Estimate against measurement, compound 3: 1.9-fold (0.27 log units) above, within the range that was stated.
By their numbers in this assay, from the lowest: compounds 2 and 3 (each within the scatter of the next); then compound 1.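

Putting 2,3,4-trimethoxyphenyl in place of 3-(trifluoromethyl)phenyl on a saturated chain carbon bound to an amine nitrogen in a ring gives a 1.1-fold higher number from compound 2 to compound 3 (0.06 log units; within the scatter) in this assay and so leaves compound 2 and compound 3 reading alike. The entering group has 12 heavy atoms and 3 hydrogen-bond acceptors, the leaving group 10 heavy atoms and 0 hydrogen-bond acceptors, and this assay does not separate the two aromatic groups at this place, which the earlier pair could not show since compound 1 and compound 2 differ in more than one place. No supporting measurement is available to explain why these two groups read alike.

Going by these compounds, two aromatic groups that read alike say little about how far this place tolerates change, so it stays open whether a plain phenyl, a pyridine ring or a cyclohexyl ring on the same chain carbon would read the same. The compounds shown also leave open what a carboxylic acid in place of the methyl ester, or a longer chain to the piperazine nitrogen, would do to the inhibition of this channel.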